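A Sulfur-Containing Ring Replaces Cyclopentyl

The source may hold more compounds than are shown below. What is called first, only, known or untested is meant among the compounds shown, and "the series" means these compounds.

Within the data shown here, compound 2 `Cc1c(C2CCCC2)c(=O)on1C(=O)N1CCCCC1` gives 6 nM in an assay (strain Wistar) for inhibition of Hormone-sensitive lipase (Rattus norvegicus), read by spectrophotometry (a higher number here means a weaker inhibitor, a lower number a stronger inhibitor), the lowest of the two numbers known so far; compound 1 `CCc1c(C)n(C(=O)N2CCCCC2)oc1=O` gives 18 nM in this assay. Among the measured compounds shown here, the one measured step, a 3.0-fold lower number from compound 1 to compound 2 (0.48 log units; beyond the scatter), came with cyclopentyl in place of ethyl on an aromatic carbon. Compound 3 `Cc1c(C2CCSCC2)c(=O)on1C(=O)N1CCCCC1` carries thian-4-yl in place of cyclopentyl on an aromatic carbon. For the measured compounds named here, that single step bears on it only loosely, showing that a ring at this carbon was accepted, and no step involves a sulfur-containing ring. The expected step is no change at the digits printed from compound 2 to compound 3 (within the scatter), within the scatter. Compound 3 is estimated at 6 nM in this assay, between 2 nM and 20 nM.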

Compound 3, half-maximal inhibitory concentration: 11 nM
For compound 3 the middle estimate is 1.8-fold (0.26 log units) below the measured one; the measured number falls inside the stated range.
By their numbers in this assay, from the lowest: compounds 2, 3 and 1 (each within the scatter of the next, the first and the last beyond it).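

In this assay, moving to thian-4-yl gives a 1.8-fold higher number from compound 2 to compound 3 (0.26 log units; within the scatter), so this aromatic carbon accepts a six-membered ring containing sulfur as well as the five-membered carbon ring. The change from ethyl to the same ring gives a 1.6-fold lower number from compound 1 to compound 3 (0.21 log units; within the scatter), so thian-4-yl cannot be separated from either of the other two groups here. No available evidence explains these numbers. From the compounds shown here alone, it remains open whether oxan-4-yl or piperidin-4-yl, with an oxygen or an amine nitrogen in place of the sulfur, would give a similar number at this carbon.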